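A Sulfonamide Enters Where a Pyrazole Was Lost

A few compounds are considered here, and "the series" means these few. Any claim that something is new, unique, unknown or untested is made for them only; others in the source may bear on it.

Compound 1 `Cc1n[nH]cc1-c1cccc2c1CCC2c1ncc[nH]1` carries a 3-methyl-1H-pyrazol-4-yl group on its core, and in a functional assay on CHO cells for agonist activity at Alpha-1D adrenergic receptor (Homo sapiens), read by FLIPR and calcium flux (a higher number here means that more compound is needed for the effect, a lower number that less compound is needed), compound 1 gives 634 nM. Compound 2 `c1ccc2c(c1)CCC2c1ncc[nH]1` has a hydrogen in that place. In this assay compound 2 reaches only a limit of the measurement, > 10000 nM. So compound 2 stands at the top of the numbers shown, at the limit of > 10000 nM in this assay, at which 1 of the 2 values shown sits, and the step of an at least 15-fold higher number from compound 1 to compound 2 (1.19 log units; beyond the scatter) is the only measured change in this set. Compound 3 `CS(=O)(=O)Nc1cccc2c1CCC2c1ncc[nH]1` differs from compound 2 by methanesulfonamido in place of hydrogen on an aromatic carbon. Within the data shown here, the one measured step that bears on this change, an at least 15-fold higher number from compound 1 to compound 2 (1.19 log units; beyond the scatter), was large, which suggests that a group entering on this carbon can move the number strongly; a methanesulfonamido group is, however, a different group from the pyrazole. Compound 3 is therefore expected to give about 3000 nM, with a range from 500 nM to 15000 nM. That estimate means an expected step of an at least 3.3-fold lower number from compound 2 to compound 3 (0.52 log units; beyond the scatter).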

Compound 3, half-maximal effective concentration: > 10000 nM
Compound 3: no number, only a limit; the forecaster's own chance of this, stated with the estimate: 40%; middle value at least 3.3-fold (0.52 log units) from the limit.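

Compound 3 stays at the limit of the measurement in this assay, so the step between compound 2 and compound 3 cannot be read. Methanesulfonamido in the place of the 3-methyl-1H-pyrazol-4-yl group gives an at least 15-fold higher number from compound 1 to compound 3 (1.19 log units; beyond the scatter), which shows that a group on this aromatic carbon does not by itself bring back a measurable effect. Of the compounds shown, only the one with the pyrazole gives a number, and the other two share the same ceiling: the limit of > 10000 nM in this assay, at which 2 of the 3 values shown sit.

From the compounds shown here alone, it remains open whether methanesulfonamido differs from hydrogen at all, as two limits cannot rank the compounds. Going by these compounds, it is also open whether a plain phenyl ring, a pyridine ring or a small amine on this carbon would give a number, and so whether the effect depends on a ring here.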